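From methyl to trifluoromethyl: a stability question

A few compounds are considered here, and "the series" means these few. Any claim that something is new, unique, unknown or untested is made for them only; others in the source may bear on it.

Of the compounds shown here, two have been measured in an ADME assay on microsomes from liver (Homo sapiens) for metabolic stability, read by LC-MS, with a stated time of 30 min, tested at 1 uM; a lower number here means that less of the compound is left, a higher number that more of the compound is left. Compound 1 `Cc1cccc(S(=O)(=O)c2ccc(CNC(=O)c3cc4cnccc4[nH]3)cc2)c1` gives 49%, the lower of the two numbers. Compound 2 `O=C(NCc1ccc(S(=O)(=O)c2ccccc2)cc1)c1cn2ccnc2cn1`, built on a different core, gives 87%, a gap beyond the usual scatter. Compound 3 `O=C(NCc1ccc(S(=O)(=O)c2cccc(C(F)(F)F)c2)cc1)c1cc2cnccc2[nH]1` keeps the core of compound 1 and differs in one place: trifluoromethyl in place of methyl on an aromatic carbon. Among the compounds with values here, no measured pair shows this same change, so its effect is not known from these data. From compound 1 the step of a number 13 percentage points higher from compound 1 to compound 3 (beyond the scatter) is expected to be a moderate rise in this assay, just beyond the scatter. Compound 3 is therefore estimated at about 62%, within 45% to 80%.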

Compound 3, percent of the compound remaining: 81%
The estimate for compound 3 lay 19 percentage points below the measured number; the measured number lies above the stated range.
By their numbers in this assay, from the lowest: compound 1; then compounds 3 and 2 (each within the scatter of the next).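

On the ring named 3-methylphenyl in compound 1, trifluoromethyl in place of methyl gives a number 32 percentage points higher from compound 1 to compound 3 (beyond the scatter) in this assay. This shows that a change at this single place, with the rest of the molecule kept the same, can alter how much compound is left by a large amount, which the first two compounds, built on different cores, could not show. Nothing available here explains the rise.

As far as these compounds go, whether a chlorine atom, an amine or a carboxylic acid at this place would give a similar step remains open. So does whether trifluoromethyl would have the same effect on another core.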